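Phenyl cap on the N-alkoxy chain of compound 3

The source may report more compounds than this note shows. Statements on the series, on what has been measured and on what is new or still open speak of the compounds shown alone.

Measured so far in an assay on HEK293 cells for inhibition of N-acylethanolamine-hydrolyzing acid amidase (Homo sapiens), read by fluorescence, with stated times of 10 min and 50 min; on this read-out higher numbers stand for weaker inhibition and lower numbers for stronger inhibition:
- compound 1, `CON1C[C@H](NC(=O)OCCCCC2CCCCC2)C1=O`: 16 nM
- compound 2, `CON1C[C@@H](NC(=O)OCCCCC2CCCCC2)C1=O`: 56 nM
- compound 3, `CCCCCON1C(=O)[C@@H](NC(=O)OCCCCC2CCCCC2)[C@@H]1C`: 387 nM

Compound 3 gives the highest number of the three in this assay; compound 2 is nearest to it and compound 1 furthest. For the measured compounds named here, the only step between compounds that differ in one place is a 3.5-fold higher number from compound 1 to compound 2 (0.54 log units; beyond the scatter), and that step rests solely on configuration, because of the fact that compounds 1 and 2 differ only in the configuration as drawn. Compound 3 differs from compounds 1 and 2 in more than one place, so its values can only be set beside theirs without a computed step.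

Compound 4 is `C[C@H]1[C@H](NC(=O)OCCCCC2CCCCC2)C(=O)N1OCCCCc1ccccc1`. Against compound 3 the change is phenyl in place of methyl on a saturated chain carbon, four bonds along the chain from an oxygen on an unsaturated carbon. Going by the values given here, no measured step touches a change of this kind: the one measured step concerns configuration, not the end of the N-alkoxy chain, so it gives no guide on direction or size here. The expectation therefore rests on compound 3 alone, with a wide range. Compound 4 is expected to give 200 nM in this assay, between 60 nM and 700 nM, which means an expected 1.9-fold lower number from compound 3 to compound 4 (0.29 log units; within the scatter), a change that may or may not lie beyond the scatter.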

Compound 4, half-maximal inhibitory concentration: 1240 nM
The estimate for compound 4 lay 6.2-fold (0.79 log units) below the measured number, and the stated range ends below it.
By their numbers in this assay, from the lowest: compound 1; then compound 2; then compound 3; then compound 4.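

In this assay, the end of this chain is sensitive to what it carries: a 3.2-fold higher number from compound 3 to compound 4 (0.51 log units; beyond the scatter). For the compounds shown here, the change is phenyl in place of methyl on a saturated chain carbon, four bonds along the chain from an oxygen on an unsaturated carbon, and it moves the read-out towards weaker inhibition, so the added aromatic ring brings no gain at this place on the core of compound 3; this is the first reading on the chain end, as the earlier single step concerned configuration only. Nothing on hand bears on why this step goes in this direction or has this size.

Still open, on these data alone, is whether a shorter link to the phenyl, as in a benzyl or phenethyl end, would give the same direction, and whether a cyclohexyl, an amine or a carboxylic acid at the chain end would read differently from phenyl. Also open, as far as these compounds go, is whether the same change would give a step of similar size on the core of compound 1 or compound 2, which lacks the ring methyl of compound 3.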